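Removing the methyl: compound 4 against compound 1

The source may report more compounds than this note shows. Statements on the series, on what has been measured and on what is new or still open speak of the compounds shown alone.

Measured compounds:
- compound 1, `COc1cc(C(=O)c2sc(-c3ccc(C)cc3)cc2N)cc(OC)c1OC`: 18 nM
- compound 2, `COc1cc(C(=O)c2sc(-c3ccc(I)cc3)cc2N)cc(OC)c1OC`: 400 nM
- compound 3, `COc1ccc(-c2cc(N)c(C(=O)c3cc(OC)c(OC)c(OC)c3)s2)cc1OC`: 40 nM

In a functional assay on L1210 cells (Mus musculus) for antiproliferative activity (a lower number here means a stronger inhibitor, a higher number a weaker inhibitor), compound 1 gives the lowest of the three numbers. Its nearest neighbour is compound 3, with a 2.2-fold higher number from compound 1 to compound 3 (0.35 log units; beyond the scatter), and the furthest is compound 2, with a 22-fold higher number from compound 1 to compound 2 (1.35 log units; beyond the scatter). Both steps alter only the aryl group on the shared core, and both raise the number, so this part of the molecule is clearly sensitive to change.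

Compound 4, `COc1cc(C(=O)c2sc(-c3ccccc3)cc2N)cc(OC)c1OC`, differs from compound 1 as follows:
hydrogen in place of methyl on an aromatic carbon

For the measured compounds named here, no measured step removes a group to leave bare hydrogen, so the two steps from compound 1 serve only as a guide: the larger substitution by iodo cost much, the smaller change to 3,4-dimethoxyphenyl cost little. Loss of the methyl is expected to sit at the modest end, weakening compound 4 by a 2.2-fold higher number from compound 1 to compound 4 (0.35 log units; beyond the scatter) in this assay. Compound 4 is therefore estimated at 40 nM, within a range of 12 nM to 150 nM.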

Compound 4, half-maximal inhibitory concentration: 11 nM
Beside the measured number, compound 4's estimate is 3.6-fold (0.56 log units) above it; measured number below the stated range.
By their numbers in this assay, from the lowest: compounds 4 and 1 (each within the scatter of the next); then compound 3; then compound 2.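

In this assay, taking the methyl away gives a 1.6-fold lower number from compound 1 to compound 4 (0.21 log units; within the scatter) and so costs nothing measurable: on this ring, the position para to a large group does not need the methyl. The bare phenyl also sets a reference for the other aryl groups, with a 3.6-fold lower number from compound 3 to compound 4 (0.56 log units; beyond the scatter) and a 36-fold lower number from compound 2 to compound 4 (1.56 log units; beyond the scatter) showing that the losses with 3,4-dimethoxyphenyl and 4-iodophenyl hold against hydrogen as well as against methyl, and that of hydrogen, methyl and iodo at this position, iodo alone stands clearly apart. No supporting data offer an explanation for this result.

Going by these compounds, whether the same position would accept an ethyl group, a chlorine atom or an amine remains open. Also open, on these data alone, is whether a single methoxy group there would match hydrogen and methyl or follow 3,4-dimethoxyphenyl.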